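A few compounds are considered here, and "the series" means these few. Any claim that something is new, unique, unknown or untested is made for them only; others in the source may bear on it.

Measured compounds:
compound 1 `c1ccc(-c2nc[nH]n2)c(NCC2=NCCN2)c1` with 3.98 nM
compound 2 `CCCn1ncnc1-c1ccccc1NCC1=NCCN1` with 251 nM
compound 3 `CCCCn1ncnc1-c1ccccc1NCC1=NCCN1` with 398 nM

In an in vitro functional assay on cells (Fibroblast) for agonist activity at Alpha-1D adrenergic receptor (Homo sapiens) (on this read-out lower numbers stand for an effect already at smaller amounts and higher numbers for an effect only at larger amounts of compound), compound 1 gives the lowest of the three numbers; compound 2 and compound 3 both lie well beyond the scatter from it, with compound 3 the furthest. Compound 2 and compound 3 carry a saturated chain on a ring nitrogen of the triazole, where compound 1 bears a hydrogen. Among the compounds with values here, the one measured step among them, a 1.6-fold higher number from compound 2 to compound 3 (0.20 log units; within the scatter), lengthens that chain and stays within the scatter. Compound 4 `Cc1n[nH]c(-c2ccccc2NCC2=NCCN2)n1` differs from compound 1 by 3-methyl-1H-1,2,4-triazol-5-yl in place of 1H-1,2,4-triazol-3-yl on an aromatic carbon. Within the data shown here, no measured step bears directly on a methyl placed on the ring carbon, so only a modest shift is expected. The step of a 2.5-fold higher number from compound 1 to compound 4 (0.40 log units; beyond the scatter) is expected to be small. Compound 4 is therefore estimated at 10 nM, between 3 nM and 40 nM.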

Compound 4, half-maximal effective concentration: < 5020 nM
Compound 4: a limit, no number (the forecaster's own chance of this, stated with the estimate: 2%); the middle value lies beyond the limit too.
By their numbers in this assay, from the lowest: compound 1; then compounds 2 and 3 (each within the scatter of the next).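

In this assay, within the data shown here, compound 4 gives < 5020 nM, which is a limit and not a number, so no step from compound 1 to compound 4 can be read. The compounds shown leave open how far 3-methyl-1H-1,2,4-triazol-5-yl in place of 1H-1,2,4-triazol-3-yl moves the number in this assay.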